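The source may report more compounds than this note shows. Statements on the series, on what has been measured and on what is new or still open speak of the compounds shown alone.

Compounds measured in an ADME assay on HepG2 cells (Homo sapiens) for cytotoxicity, read by luminescence, with a stated time of 72 h; a higher number here means that more compound is needed for the effect, a lower number that less compound is needed:
Compound 1 `CCOC(=O)c1c(-c2cccc(OC(F)(F)F)c2)[nH]c2cc(OC)ccc2c1=O`: > 21500 nM
Compound 2 `CCOC(=O)c1c(-c2cccc(OC)c2)[nH]c2cc(OC(F)(F)F)ccc2c1=O`: > 21500 nM

Compound 2 gives > 21500 nM as a limit of the assay and not a number. Compound 1 gives > 21500 nM as a limit too. Compound 3 `CCOC(=O)c1c(-c2cccc(OC(F)(F)F)c2)[nH]c2cc(OC(F)(F)F)ccc2c1=O` carries trifluoromethyl in place of methyl on an oxygen on an aromatic ring. Among the compounds with values here, no measured step shows this change. Within the data shown here, the only guide for compound 2 is the limit of > 21500 nM in this assay, at which 2 of the 2 values shown sit, and so no step beyond the scatter is expected in this assay in either direction. The estimated step of a number no higher from compound 2 to compound 3 (the limit leaves the size open) is expected to be small. Compound 3 is expected at 21500 nM with a range of 10000 nM to 30000 nM and is expected to be a limit again.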

Compound 3, half-maximal effective concentration: > 21500 nM
Compound 3 was reported as a limit; the forecaster's own chance of this, stated with the estimate: 75%; the middle value sits exactly at the limit.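

Compound 3 gives > 21500 nM in this assay, a limit of the assay and not a number. The steps from compound 1 and from compound 2 to compound 3 cannot be read. The compounds shown leave open what effect, if any, the swap of methoxy to trifluoromethoxy has in this assay.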